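A few compounds are considered here, and "the series" means these few. Any claim that something is new, unique, unknown or untested is made for them only; others in the source may bear on it.

Two members of the series have a number in an assay on U2OS cells for activation of nuclear factor erythroid 2-related factor 2 (Homo sapiens), read by beta-arrestin recruitment, with a stated time of 6 h; on this read-out higher numbers stand for an effect only at larger amounts of compound and lower numbers for an effect already at smaller amounts. Compound 1 `O=S(=O)(/C=C/c1cccnc1)c1ccccc1Cl` gives 2850 nM. Compound 2 `O=S(=O)(/C=C/c1ccncc1)c1ccccc1F` gives 760 nM, the lowest of the two numbers shown, with compound 1 the nearest and higher by a gap beyond the usual scatter. Compound 3 `O=S(=O)(/C=C/c1ccncc1)c1ccccc1Cl` is not yet measured; it differs from compound 2 by chloro in place of fluoro on an aromatic carbon. Among the measured compounds shown here, no measured pair isolates this change, so its size is unknown. Compound 3 is expected to show a modest rise, the step of a 1.6-fold higher number from compound 2 to compound 3 (0.20 log units; within the scatter) possibly inside the scatter. The estimate for compound 3 is 1200 nM, from 500 nM to 3000 nM.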

Compound 3, half-maximal effective concentration: 781 nM
Beside the measured number, compound 3's estimate is 1.5-fold (0.19 log units) above it; the measured number falls inside the stated range.
By their numbers in this assay, from the lowest: compounds 2 and 3 (each within the scatter of the next); then compound 1.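

Chloro in place of fluoro on an aromatic carbon, ortho to a large group, gives a 1.0-fold higher number from compound 2 to compound 3 (0.01 log units; within the scatter) in this assay, so this position accepts either group when pyridin-4-yl is present. Pyridin-4-yl in place of pyridin-3-yl gives a 3.6-fold lower number from compound 1 to compound 3 (0.56 log units; beyond the scatter), so of the two changes only this one moves the number. Nothing at hand explains either step.

As far as these compounds go, whether an amine or a methoxy group at this aromatic carbon would keep the number remains open. Also open, from the compounds shown here alone, is whether fluoro and chloro match when pyridin-3-yl is present.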